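Chloro for methoxy on the phenylpiperazine of compound 2

The source may report more compounds than this note shows. Statements on the series, on what has been measured and on what is new or still open speak of the compounds shown alone.

Measured compounds:
compound 1, `CCCc1nc(-c2ccccc2)c(CNCCCN2CCN(c3cccc(C(F)(F)F)c3)CC2)o1`, 51.6%
compound 2, `CCCc1nc(-c2ccccc2)c(CNCCCN2CCN(c3cccc(OC)c3)CC2)o1`, 36.4%
compound 3, `CCCc1nc(-c2ccccc2)c(CNCCN2CCN(c3ccc(F)cc3)CC2)o1`, 54.1%

In an assay on HEK293 cells for inhibition of Voltage-dependent T-type calcium channel subunit alpha-1G (Homo sapiens), read by fluorescence, tested at 10 uM (a lower number here means less inhibition, a higher number more inhibition at the concentration tested (going by the name of the read-out)), compound 2 gives the lowest of the three numbers: compound 1 stands higher by a margin beyond the scatter, and compound 3 stands higher still, also beyond the scatter. Compound 4, `CCCc1nc(-c2ccccc2)c(CNCCCN2CCN(c3cccc(Cl)c3)CC2)o1`, is not yet measured. It differs from compound 2 in one place: chloro in place of methoxy on an aromatic carbon.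

Going by the values given here, only one measured step touches this position of the ring, and it runs the other way: a number 15.2 percentage points lower from compound 1 to compound 2 (beyond the scatter). Among the compounds with values here, no measured compound carries chloro, so nothing shows directly how chloro compares with either trifluoromethyl or methoxy here. The step from compound 1 to compound 2 shows that exchanging the group at this position can move the inhibition by a modest amount, with methoxy the lower of the two. For compound 4 a rise from compound 2 is expected, of the order of a number 11.6 percentage points higher from compound 2 to compound 4 (beyond the scatter), because compound 1 with trifluoromethyl sits at 51.6% and the replacement of methoxy plausibly returns the inhibition toward that level. Compound 4 is therefore estimated at 48%, with a range from 33% to 63%.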

Compound 4, a percentage reported as inhibition, at one concentration (the size of the read-out at that concentration, not a potency): 65.9%
Compound 4: middle estimate off by 17.9 percentage points, on the low side; measured number outside the range, above it.
By their numbers in this assay, from the lowest: compound 2; then compounds 1 and 3 (each within the scatter of the next); then compound 4.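

In this assay, the change from 3-methoxyphenyl to 3-chlorophenyl gives a number 29.5 percentage points higher from compound 2 to compound 4 (beyond the scatter), which shows that this place on the six-membered aromatic ring responds more strongly to substitution than the earlier trifluoromethyl-to-methoxy step alone had revealed. Chloro also surpasses trifluoromethyl, with a number 14.3 percentage points higher from compound 1 to compound 4 (beyond the scatter), so trifluoromethyl does not mark the upper end of the inhibition reached here, and the three groups now rank methoxy, trifluoromethyl, chloro, with each step beyond the scatter. Nothing available accounts for this order, which therefore remains an observation about these three compounds alone.

The compounds shown leave open where a bromo, methyl or nitrile group would fall in this order at the same place, and whether chloro would keep its lead over methoxy and trifluoromethyl with the chain found in compound 3. As all these readings come from a single concentration, they also leave open whether the same order would hold for potency.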